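The source may hold more compounds than are shown below. What is called first, only, known or untested is meant among the compounds shown, and "the series" means these compounds.

In a functional assay on HepG2 cells (Homo sapiens) for inhibition, read by MTT assay, with a stated time of 72 h (a higher number here means a weaker inhibitor, a lower number a stronger inhibitor), compound 1 `COc1ccc(-c2nnc(SCCCN3CCN(c4nc5ccccc5s4)CC3)o2)cc1` gives 134000 nM and compound 2 `Clc1ccc(-c2nnc(SCCCN3CCN(c4nc5ccccc5s4)CC3)o2)cc1` gives 87700 nM within the scatter of compound 1. Compound 3 `Brc1ccc(-c2nnc(SCCCN3CCN(c4nc5ccccc5s4)CC3)o2)cc1` differs from compound 2 in a single group (bromo in place of chloro on an aromatic carbon) with bromo in place of chloro on an aromatic carbon. Within the data shown here, the one measured step at that place is a 1.5-fold lower number from compound 1 to compound 2 (0.18 log units; within the scatter) for chloro in place of methoxy. Among the measured compounds shown here, with only that small step to go on, no shift beyond the scatter is expected in this assay for this change. The expected step is a 1.0-fold lower number from compound 2 to compound 3 (0.01 log units; within the scatter) and neither direction is favoured. The expected value for compound 3 is 85000 nM with an estimated range from 42000 nM to 170000 nM in this cell test.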

Compound 3, half-maximal inhibitory concentration: 103000 nM
Compound 3: middle estimate off by 1.2-fold (0.08 log units), on the low side; the measured number falls inside the stated range.
By their numbers in this assay, from the lowest: compounds 2, 3 and 1 (each within the scatter of the next).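

In this assay, going from 4-chlorophenyl to 4-bromophenyl gives a 1.2-fold higher number from compound 2 to compound 3 (0.07 log units; within the scatter), and bromo in place of methoxy gives a 1.3-fold lower number from compound 1 to compound 3 (0.11 log units; within the scatter). At this position, on an aromatic carbon para to a large group, methoxy, chloro and bromo now all read alike, and the two halogens cannot be told apart. No evidence on hand bears on this result. Going by these compounds, whether an amine or a carboxylic acid at this position would shift the number beyond the scatter stays open. So does whether a longer chain elsewhere on the shared core would.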